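Mirror-Image Pair: Cytotoxicity of Two Triazole Enantiomers

The compounds below may be only part of what the source reports. "The series", "measured", "known", "first", "only" and "open" are said of these compounds alone.

Measured so far:
compound 1, `CC[C@@H](CCn1cncn1)c1ccc(C)cc1`, 79.4 ug/mL
compound 2, `CCCC[C@H](CCn1cncn1)c1ccc(Cl)cc1Cl`, 10.1 ug/mL

Both compounds were tested in an ADME assay on RD cells (Homo sapiens) for cytotoxicity, read by MTT assay, with a stated time of 3 days; a lower number here means that less compound is tolerated, a higher number that more compound is tolerated. Compound 1 gives 79.4 ug/mL, while compound 2 gives 10.1 ug/mL, which is the lowest of the two numbers; the gap between them lies beyond the scatter, so compound 2 is the less tolerated of the pair.

Compound 3, `CCCC[C@@H](CCn1cncn1)c1ccc(Cl)cc1Cl`, has not yet been measured. The difference from compound 2 is the two compounds have the same atoms and bonds and differ only in configuration as drawn: 1 of 1 stereo elements differ; a stereocentre at a saturated chain carbon is drawn R in compound 2 and S in compound 3. Within the data shown here, no step between measured compounds is known for such a change; only the two values above are available.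

In this assay compound 3 is expected to stay close to compound 2, with a step from a 1.1-fold higher number from compound 2 to compound 3 (0.04 log units; within the scatter) that should not exceed the scatter, because compound 2 already gives 10.1 ug/mL and nothing enters or leaves. The estimate for compound 3 is 11 ug/mL, within 4.5 ug/mL to 27 ug/mL.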

Compound 3, half-maximal cytotoxic concentration: 1.9 ug/mL
Beside the measured number, compound 3's estimate is 5.8-fold (0.76 log units) above it, outside the stated range (below it).
By their numbers in this assay, from the lowest: compound 3; then compound 2; then compound 1.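

In this assay, the step of a 5.3-fold lower number from compound 2 to compound 3 (0.73 log units; beyond the scatter) shows that the stereocentre at a saturated chain carbon matters: moving from R to S as drawn leaves compound 3 less tolerated than compound 2. The earlier compounds shown here could not show this, as they differed in more than one place and so could not isolate the configuration. Nothing enters or leaves in this step, which makes the spatial arrangement at this one carbon the only structural source of the gap: the fact that compounds 2 and 3 differ only in the configuration as drawn.

As far as these compounds go, this is a single mirror-image pair, so it remains open whether the S form would also be the less tolerated one in compounds carrying a different group, such as a longer chain or an amine. The compounds shown also leave open how the cells respond to this change and why.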